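A few compounds are considered here, and "the series" means these few. Any claim that something is new, unique, unknown or untested is made for them only; others in the source may bear on it.

- compound 1 `O=C(Nc1ccccn1)c1cccc(Nc2ncc(F)c(Nc3ccc(F)cc3)n2)c1`: 13700 nM
- compound 2 `O=C(Nc1nccs1)c1cccc(Nc2ncc(F)c(Nc3ccc(F)cc3)n2)c1`: > 10000 nM
- compound 3 `O=C(c1cccc(Nc2ncc(F)c(Nc3ccc(F)cc3)n2)c1)N1CCCCC1`: 13800 nM

All three compounds were tested in a functional assay on KBVIN cells (Homo sapiens) for antiproliferative activity, read by sulforhodamine B assay, with a stated time of 3 days; a lower number here means a stronger inhibitor of growth, a higher number a weaker inhibitor of growth. For compound 2 the result is a limit, > 10000 nM, and not a number. Compound 3 stands at 13800 nM, level with compound 1 within the scatter, as the step of a 1.0-fold higher number from compound 1 to compound 3 (0.00 log units; within the scatter) shows.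

The next compound, compound 4 `O=C(Nc1cccc(Nc2ncc(F)c(Nc3ccc(F)cc3)n2)c1)c1ccncc1`, carries ((pyridin-4-yl)carbonyl)amino in place of (piperidin-1-yl)carbonyl on an aromatic carbon, meta to a large group: ((pyridin-4-yl)carbonyl)amino in place of (piperidin-1-yl)carbonyl on an aromatic carbon.

For the measured compounds named here, no measured step makes this same change, so the evidence is indirect. The closest guide is a 1.0-fold higher number from compound 1 to compound 3 (0.00 log units; within the scatter), where piperidin-1-yl replaced (pyridin-2-yl)amino on a carbonyl carbon and the number stayed within the scatter. The other two steps, a step that the limit leaves unreadable from compound 1 to compound 2 and a step that the limit leaves unreadable from compound 2 to compound 3, cannot be sized. Going by the values given here, they add only that the thiazole compound also gave no number below its limit, as recorded in the limit of > 10000 nM in this assay, at which 1 of the 3 values shown sits.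

A shift beyond the scatter is therefore not expected in this assay, though the uncertainty is wide. The expected step is a 1.3-fold lower number from compound 3 to compound 4 (0.10 log units; within the scatter). The estimate for compound 4 is 11000 nM, with an expected range from 4500 nM to 25000 nM.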

Compound 4, concentration for 50% growth inhibition: 4570 nM
Compound 4: middle estimate off by 2.4-fold (0.38 log units), on the high side; the range from low to high includes it.
By their numbers in this assay, from the lowest: compound 4; then compounds 1 and 3 (each within the scatter of the next).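

Among the earlier compounds, the one readable change at this position left the number within the scatter in this assay, so exchanging one carbonyl-linked group for another had shown nothing. For the compounds shown here, with ((pyridin-4-yl)carbonyl)amino on the aromatic carbon, the position moves the number beyond the scatter for the first time, and the size is the same from either earlier starting point: a 3.0-fold lower number from compound 3 to compound 4 (0.48 log units; beyond the scatter) and a 3.0-fold lower number from compound 1 to compound 4 (0.48 log units; beyond the scatter). The thiazole series points the same way, with an at least 2.1-fold lower number from compound 2 to compound 4 (0.34 log units; beyond the scatter), but its starting point is only a limit and not a number: the limit of > 10000 nM in this assay, at which 1 of the 4 values shown sits.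

The entering group differs from those it replaces both in attaching to the aromatic carbon through the amide nitrogen and in carrying a pyridin-4-yl ring, and the compounds shown do not separate these two changes. A (pyridin-2-yl)carbonylamino or plain benzoylamino group in the same place would tell whether the reversed link alone carries the step, or whether the ring nitrogen's position also counts.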